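The source may report more compounds than this note shows. Statements on the series, on what has been measured and on what is new or still open speak of the compounds shown alone.

Three compounds have been measured in a physicochemical assay for lipophilicity, using the shake flask method, in phosphate buffer, measured as octanol-water partition, at pH 7.4; on this read-out lower numbers stand for lower lipophilicity and higher numbers for higher lipophilicity:

Compound 1, `CC[C@@H](c1ccc(C(=O)O)c(Oc2cccc(Cl)c2)c1F)N1CCC[C@H](n2cc(C)c(=O)[nH]c2=O)C1`, gives 0.11.
Compound 2, `Cc1cn([C@H]2CCCN(Cc3ccc(C(=O)O)c(Oc4cccc(Cl)c4)c3F)C2)c(=O)[nH]c1=O`, gives -0.59.
Compound 3, `CC[C@@H](c1ccc(C(=O)O)c(Oc2cccc(Cl)c2)c1OC)N1CCC[C@H](n2cc(C)c(=O)[nH]c2=O)C1`, gives -0.02.

Compound 2 differs from compound 1 in one place, (hydrogen in place of ethyl on a saturated chain carbon bound to an amine nitrogen in a ring and an aromatic carbon). This change produced a number 0.70 log units lower from compound 1 to compound 2 (beyond the scatter). Compound 3 differs from compound 1 in another way, (methoxy in place of fluoro on an aromatic carbon); this gave a number 0.13 log units lower from compound 1 to compound 3 (within the scatter), so compound 1 and compound 3 are not told apart by this assay.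

Compound 4, `COc1c(CN2CCC[C@H](n3cc(C)c(=O)[nH]c3=O)C2)ccc(C(=O)O)c1Oc1cccc(Cl)c1`, has not yet been measured in this assay. It differs from compound 3 as hydrogen in place of ethyl on a saturated chain carbon bound to an amine nitrogen in a ring and an aromatic carbon. Among the compounds with values here, this is the same change as the one from compound 1 to compound 2, made on the core of compound 3 rather than on the core of compound 1; the two cores differ as described for compound 1 and compound 3. The change occurs twice among these compounds, once measured and once not.

For compound 4 a step of about a number 0.70 log units lower from compound 3 to compound 4 (beyond the scatter) is expected in this assay, beside the measured one, because a number 0.70 log units lower from compound 1 to compound 2 (beyond the scatter) was found for the same change on a core that itself is not told apart from the core of compound 3 by a number 0.13 log units lower from compound 1 to compound 3 (within the scatter). Compound 4 is therefore estimated to give -0.72, with a range expected between -1.05 and -0.4.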

Compound 4, distribution coefficient: -0.77
Estimate against measurement, compound 4: 0.05 log units above; low and high end bracket the measured number.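

In this assay hydrogen in place of ethyl gave a number 0.75 log units lower from compound 3 to compound 4 (beyond the scatter) on the methoxy core and so ran the same way, and likewise beyond the scatter, as a number 0.70 log units lower from compound 1 to compound 2 (beyond the scatter) on the fluoro core, which shows the change carrying over between these two cores. The two compounds without ethyl, at a number 0.18 log units lower from compound 2 to compound 4 (within the scatter) apart, are not told apart by this assay and so keep the relation already seen for the two ethyl compounds, which also lay within the scatter of each other. All of this rests on a single pair of cores that differ in one place, so it says nothing about cores that differ more, and nothing given here bears on why the step has the size it has.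

The compounds shown leave open how the read-out moves with methyl or a longer chain such as propyl on the saturated chain carbon bound to an amine nitrogen in a ring and an aromatic carbon, since only ethyl and hydrogen appear there. They also leave open whether the same step would hold with a third group, such as a nitrile, on the aromatic carbon that carries fluoro or methoxy.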